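This account rests on a few compounds, and the source may have more. Where it says the series, first, only, none or still open, it means among the compounds named here.

In a functional assay on MDA-MB-231 cells (Homo sapiens) for inhibition, read by sulforhodamine B assay, with a stated time of 72 h (on this read-out higher numbers stand for weaker inhibition of growth and lower numbers for stronger inhibition of growth), compound 1 `CN1CCN(C(=O)/C=C/c2ccncc2-c2ccc3ccccc3c2)CC1` gives > 10000 nM, and this is a limit of the assay, not a number. Within the data shown here, compound 2 `CNC(=O)/C=C/c1ccncc1-c1ccc2ccccc2c1` gives 8680 nM, the only true number so far, so it has no measured neighbour to be ranked against. The next compound, compound 3 `NNC(=O)CCc1ccncc1-c1ccc2ccccc2c1`, carries 2-(aminocarbamoyl)ethyl in place of 2-(methylcarbamoyl)ethenyl on an aromatic carbon. Among the measured compounds shown here, only one measured step offers any guide. It is an at least 1.1-fold lower number from compound 1 to compound 2 (0.06 log units; that floor lies within the scatter), and it changes the group on the carbonyl carbon while leaving the rest of the chain alone. For the measured compounds named here, that step gives no sign of a large effect, but no measured step tests the loss of a double bond from the chain. A second point of caution is the limit of > 10000 nM in this assay, at which 1 of the 2 values shown sits. There is therefore no basis for expecting a clear move in either direction, and a reported limit would be no surprise. The expected change is a 1.1-fold lower number from compound 2 to compound 3 (0.04 log units; within the scatter), which stays within the usual scatter. Compound 3 is estimated at 8000 nM, with an expected range of 2500 nM to 10000 nM.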

Compound 3, concentration for 50% growth inhibition: > 10000 nM
Compound 3 was reported as a limit; the forecaster's own chance of this, stated with the estimate: 45%; middle value at least 1.2-fold (0.09 log units) from the limit.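

In this assay compound 3 gives > 10000 nM, which is a limit of the assay and not a number. This is the first change shown at this aromatic carbon, opposite the ring nitrogen, rather than at the far end of the chain: putting 2-(aminocarbamoyl)ethyl in place of 2-(methylcarbamoyl)ethenyl gives an at least 1.1-fold higher number from compound 2 to compound 3 (0.06 log units; that floor lies within the scatter), so the new group brings no sign of stronger inhibition of growth, while any loss cannot be sized. The chain's double bond and its end group change together in this step, and the room for reading any change in this small set is narrow: the limit of > 10000 nM in this assay, at which 2 of the 3 values shown sit.

As far as these compounds go, whether the double bond or the end group matters more stays open, and 2-(methylcarbamoyl)ethyl, which keeps the methylamide end on a chain without the double bond, would separate the two. Also open, from the compounds shown here alone, is how a carboxylic acid, a simple amine or a longer chain at this same place on the shared core would read in this assay.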